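This account rests on a few compounds, and the source may have more. Where it says the series, first, only, none or still open, it means among the compounds named here.

The measurements so far in an ADME assay on liver for metabolic stability, with Liver microsome (Homo sapiens) as the target, read by LC-MS, using microsomes; a lower number here means slower removal, a higher number faster removal of the compound:

Compound 1 `O=C(NCc1cc(Cl)ccc1-n1cnnn1)[C@@H]1C[C@@H]2C[C@@H]2N1C(=O)[C@H](O)Cc1ccccn1` gives 17 mL.min-1.g-1.
Compound 2 `COC(C)(C)[C@@H](O)C(=O)N1N=CC[C@H]1C(=O)NCc1cc(Cl)ccc1-n1cnnn1` gives < 12 mL.min-1.g-1, which is a limit of the assay rather than a number.
Compound 3 `CC(C)(C)C[C@@H](O)C(=O)N1OCC[C@H]1C(=O)NCc1cc(Cl)ccc1-n1cnnn1` gives < 12 mL.min-1.g-1, which is likewise a limit of the assay rather than a number.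

Compound 1 is thus the only one of the three with a number in this assay; the other two results sit at the limit of < 12 mL.min-1.g-1 in this assay, at which 2 of the 3 values shown sit. Among the compounds with values here, no pair of the measured compounds differs in a single place, so there is no measured step to lean on, and the three structures share their core only in part.

Compound 4 `O=C(NCc1cc(Cl)ccc1-n1cnnn1)[C@@H]1C[C@@H]2C[C@@H]2N1C(=O)[C@H](O)c1cccc(Cl)c1` has not yet been measured. It departs from compound 1 by 3-chlorophenyl in place of (pyridin-2-yl)methyl on a saturated chain carbon bound to a carbonyl carbon and an oxygen on a saturated carbon. Within the data shown here, with no measured step to compare, the expectation rests on compound 1 alone. The reading of compound 4 in this assay is expected to move, if at all, toward faster removal, by a step of a 1.5-fold higher number from compound 1 to compound 4 (0.17 log units; within the scatter) that is estimated to lie close to the usual scatter. Compound 4 is therefore estimated at 25 mL.min-1.g-1, in a range from 12 mL.min-1.g-1 to 55 mL.min-1.g-1. A result reported only as a limit of the assay cannot be excluded for compound 4.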

Compound 4, intrinsic clearance in microsomes: > 500 mL.min-1.g-1
Compound 4: only a limit was reported; the forecaster's own chance of this, stated with the estimate: 20%; at least 20-fold (1.30 log units) between middle value and limit.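

Within the data shown here, until now no step existed between measured compounds, so nothing showed how much this position could matter. In this assay, placing 3-chlorophenyl in place of (pyridin-2-yl)methyl on a saturated chain carbon bound to a carbonyl carbon and an oxygen on a saturated carbon, with the rest of compound 1 unchanged, gives an at least 29-fold higher number from compound 1 to compound 4 (1.46 log units; beyond the scatter), so this single change is enough to take the compound from a measurable reading to the upper end of what the assay reports. The result for compound 4, > 500 mL.min-1.g-1, is a limit of the assay and not a number, and compound 4 stands alone there: the limit of > 500 mL.min-1.g-1 in this assay, at which 1 of the 4 values shown sits.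

The change removes the ring nitrogen and the methyl link and brings in a chlorine all at once, so the compounds shown cannot tell which of these carries the step. As far as these compounds go, a benzyl group or an unsubstituted phenyl on the same carbon would begin to separate them, and whether the same exchange would act alike on the different cores of compound 2 and compound 3 also remains open.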